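Nitrogen substituent swap on the triazole series: allyl to phenyl

The source may report more compounds than this note shows. Statements on the series, on what has been measured and on what is new or still open speak of the compounds shown alone.

Compound 3 `C=CCn1c(SC/C(=N/O)c2ccccc2)nnc1-c1cc(OC)c(OC)c(OC)c1` gives 61% in a functional assay on the whole organism (strain albino) for inhibition, with Rattus norvegicus as the target, read by paw edema, with a stated time of 1 h, at a dose of 0.28 mmol/kg by the oral route (a lower number here means less inhibition, a higher number more inhibition at the dose given (going by the name of the read-out)), the second highest of the three numbers, with compound 2 `CCn1c(SC/C(=N/O)c2ccccc2)nnc1-c1cc(OC)c(OC)c(OC)c1` at 63% and compound 1 `COc1ccc(-c2nnc(SC/C(=N/O)c3ccccc3)n2-c2ccccc2)cc1OC` at 55% both within the scatter of it. Among the compounds with values here, the only change so far at the aromatic nitrogen, a number 2 percentage points lower from compound 2 to compound 3 (within the scatter), stayed within the scatter. Compound 4 `COc1cc(-c2nnc(SC/C(=N/O)c3ccccc3)n2-c2ccccc2)cc(OC)c1OC` differs from compound 3 by phenyl in place of allyl on an aromatic nitrogen. Compound 1 already carries a phenyl on that nitrogen, though with a different methoxy pattern, and its value lies within the scatter of compound 3. The step of a number 4 percentage points lower from compound 3 to compound 4 (within the scatter) is therefore expected to stay within the scatter, possibly trending slightly lower. Compound 4 is estimated at 57%, with a range of 47% to 67%.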

Compound 4, a percentage reported as inhibition, in the whole organism at one dose (the size of the read-out at that dose, not a potency): 61%
Compound 4: the middle estimate sits 4 percentage points below what was measured; the measured number falls inside the stated range.
By their numbers in this assay, from the lowest: compounds 1, 3, 4 and 2 (each within the scatter of the next).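

Phenyl on the aromatic nitrogen, a ring in place of an open chain, reads the same as the chains: no change at the digits printed from compound 3 to compound 4 (within the scatter), and a number 2 percentage points lower from compound 2 to compound 4 (within the scatter). With phenyl held on that nitrogen, the added methoxy is also unresolved in this assay: a number 6 percentage points higher from compound 1 to compound 4 (within the scatter). No data on hand explain why these groups read alike.

Open, from the compounds shown here alone, is whether an aminoethyl chain or a chain ending in a carboxylic acid on this nitrogen would stay within the scatter. At a single dose and time, these numbers give no potency order.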